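The compounds below may be only part of what the source reports. "The series", "measured", "known", "first", "only" and "open" are said of these compounds alone.

Compound 1 `C/C(=N\N=C1\N=C(c2cc3ccccc3o2)CS1)c1nc(-c2ccccc2)[nH]c1C`: 39.9%
Compound 2 `C/C(=N\NC(=O)CC#N)c1nc(-c2ccccc2)[nH]c1C`: 48.2%

Both were run in a functional assay, tested at 2 mM; on this read-out higher numbers stand for more inhibition at the one concentration tested (going by the name of the read-out) and lower numbers for less inhibition. Compound 1 gives 39.9%, and compound 2 gives 48.2%; the two numbers lie within the usual scatter of each other, so neither stands apart. Compound 3 `C/C(=N\N=C1\N=C(c2ccccc2)CS1)c1nc(-c2ccccc2)[nH]c1C` has not been measured. It differs from compound 1 in one place: phenyl in place of 1-benzofuran-2-yl on a carbon with a double bond to nitrogen. Among the compounds with values here, no measured pair shows a change of this kind, so nothing beyond the two numbers guides the expectation. The expected step is a number 4.9 percentage points lower from compound 1 to compound 3 (within the scatter), none beyond the scatter. Compound 3 is estimated at 35%, in a range from 10% to 60%.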

Compound 3, a percentage reported as inhibition, at one concentration (the size of the read-out at that concentration, not a potency): 79.4%
The estimate for compound 3 lay 44.4 percentage points below the measured number; the measured number lies above the stated range.
By their numbers in this assay, from the lowest: compounds 1 and 2 (each within the scatter of the next); then compound 3.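

In this assay, the group on the carbon with a double bond to nitrogen of the five-membered ring clearly matters: phenyl in place of 1-benzofuran-2-yl gives a number 39.5 percentage points higher from compound 1 to compound 3 (beyond the scatter) with the rest of the molecule unchanged. Within the data shown here, this is the first sign that the read-out responds to a change at this position, though it rests on a single pair. No measurement on hand explains the step. Still open, on these data alone, is how other groups here would behave, such as methyl, pyridin-2-yl or a phenyl ring carrying an amine or a carboxylic acid.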